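A few compounds are considered here, and "the series" means these few. Any claim that something is new, unique, unknown or untested is made for them only; others in the source may bear on it.

Compound 1 `O=C(c1cc2cnc(Nc3ccc(N4CCNCC4)cn3)nc2n1C1CCCC1)N1CCCCC1`: 39600 nM
Compound 2 `COc1ccc(NC(=O)c2cc3cnc(Nc4ccc(N5CCNCC5)cn4)nc3n2C2CCCC2)c(OC)c1`: 2230 nM

Going by the values given here, in a functional assay on MIA PaCa-2 cells (Homo sapiens) for inhibition, read by MTT assay (a lower number here means a stronger inhibitor, a higher number a weaker inhibitor), compound 2 has the lower of the two numbers measured so far, which makes it the stronger inhibitor of the pair. The next molecule, compound 3 `O=C(Nc1ccccc1Cl)c1cc2cnc(Nc3ccc(N4CCNCC4)cn3)nc2n1C1CCCC1`, keeps the shared core and the amide but changes the group at the end of the amide: 2-chlorophenyl in place of 2,4-dimethoxyphenyl on an amide-type nitrogen. In words, 2-chlorophenyl stands in place of 2,4-dimethoxyphenyl on an amide-type nitrogen.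

Among the compounds with values here, only one measured step bears on this change: an 18-fold lower number from compound 1 to compound 2 (1.25 log units; beyond the scatter). That step was large, but it exchanged piperidin-1-yl for (2,4-dimethoxyphenyl)amino, whereas compound 2 and compound 3 both carry a substituted phenyl on that nitrogen. Within the data shown here, no measured pair shows one substituted phenyl swapped for another, so the data favour neither direction, and no step beyond the scatter is expected in this assay. The estimate therefore means a 1.1-fold higher number from compound 2 to compound 3 (0.05 log units; within the scatter). The expected value for compound 3 is 2500 nM, with an estimated range from 900 nM to 7500 nM.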

Compound 3, half-maximal inhibitory concentration: 2170 nM
For compound 3 the middle estimate is 1.2-fold (0.06 log units) above the measured one, and the stated range covers the measured number.
By their numbers in this assay, from the lowest: compounds 3 and 2 (each within the scatter of the next); then compound 1.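

In this assay, the step of a 1.0-fold lower number from compound 2 to compound 3 (0.01 log units; within the scatter) shows that on this amide-type nitrogen, 2-chlorophenyl and 2,4-dimethoxyphenyl cannot be told apart, even though the change removes both oxygen atoms and brings in a chlorine. The drop from the piperidin-1-yl amide also appears with a second substituted phenyl, as an 18-fold lower number from compound 1 to compound 3 (1.26 log units; beyond the scatter) shows, so among these compounds it does not depend on the 2,4-dimethoxy pattern. No measurement shown here explains why the two substituted phenyl groups match or why both separate so clearly from piperidin-1-yl.

Compound 2 and compound 3 both carry the amide hydrogen and an aromatic ring where compound 1 has neither, so the compounds shown cannot say which of these two features matters more. A cyclohexylamino group would keep the hydrogen without the aromatic ring, an N-methyl-N-phenylamino group would keep the ring without the hydrogen, and an unsubstituted phenyl on the same nitrogen would show whether the ring needs any substituent at all.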